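A few compounds are considered here, and "the series" means these few. Any claim that something is new, unique, unknown or untested is made for them only; others in the source may bear on it.

Working notes on the series. In an assay on isolated protein for inhibition of protein kinase C zeta type (Homo sapiens), read by mobility shift assay, tested at 30 uM (on this read-out higher numbers stand for more inhibition at the one concentration tested (going by the name of the read-out) and lower numbers for less inhibition), compound 1 `Nc1n[nH]c2cc(-c3ccccn3)[nH]c(=O)c12` gives 3% and compound 2 `Nc1n[nH]c2cc(-c3cccs3)[nH]c(=O)c12` gives -27%. Compound 3 `Cc1cc2nn(-c3ccccc3)c(N)c2c(=O)[nH]1`, which carries a methyl in place of the aromatic substituent of the other two and a phenyl on a ring nitrogen, gives -49% in this assay. Among the three numbers compound 3 stands lowest: its nearest neighbour is compound 2, whose number lies higher by an amount beyond the scatter, and its furthest is compound 1, higher by a still larger amount, also beyond the scatter. Within the data shown here, all three numbers sit at or under zero, so none of the measured compounds shows appreciable inhibition at the single concentration tested.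

Compound 4 `Nc1c2c(=O)[nH]c(-c3ccccn3)cc2nn1-c1ccccc1` has not yet been measured in this assay. It differs from compound 3 as follows: pyridin-2-yl in place of methyl on an aromatic carbon. Among the measured compounds shown here, no pair of measured compounds differs in exactly this way, so the size of the step cannot be read off directly. Compound 1 carries the same pyridin-2-yl group and gives 3%, the highest of the three; compound 3 with its methyl gives the lowest. For the measured compounds named here, an upward step is therefore expected, though a modest one, since no compound here reaches a meaningful degree of inhibition. The expected step in this assay is a number 34 percentage points higher from compound 3 to compound 4 (beyond the scatter). For compound 4 the estimate is -15%, within a range from -50% to 20%.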

Compound 4, a percentage reported as inhibition, at one concentration (the size of the read-out at that concentration, not a potency): 3%
The estimate for compound 4 lay 18 percentage points below the measured number; the measured number falls inside the stated range.
By their numbers in this assay, from the lowest: compound 3; then compound 2; then compounds 1 and 4 (each within the scatter of the next).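

In this assay, among these compounds, pyridin-2-yl in place of methyl on the aromatic carbon next to the ring nitrogen gives a number 52 percentage points higher from compound 3 to compound 4 (beyond the scatter), the only step that can be read directly, so the number at this position responds to the change when the phenyl sits on the ring nitrogen. The step ends near zero, however: compound 4 gives 3% and compound 1, which carries the same pyridin-2-yl without that phenyl, gives 3%, two values within the scatter of each other, so the change brings no appreciable inhibition at the one concentration tested. No measurement in hand explains the size of the step.

As far as these compounds go, whether an amine, a carboxylic acid or a longer chain such as butyl on this aromatic carbon would move the number beyond that of pyridin-2-yl remains open. Also open, from the compounds shown here alone, is whether the step holds for other aromatic rings at this carbon, such as phenyl, and whether the same change would look different in a full concentration series rather than at one concentration.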